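A benzyloxycarbonyl group added to compound 3

The source may report more compounds than this note shows. Statements on the series, on what has been measured and on what is new or still open speak of the compounds shown alone.

In a functional assay on A549 cells (Homo sapiens) for antiproliferative activity, read by MTT assay, with a stated time of 48 h (a lower number here means a stronger inhibitor, a higher number a weaker inhibitor), compound 1 (`c1ccc(-c2nn(-c3ccccc3)cc2-c2nc3ccccc3[nH]2)cc1`) gives 2710 nM and compound 3 (`Fc1ccc(-c2nn(-c3ccccc3)cc2-c2nc3ccccc3[nH]2)cc1`) gives 1510 nM on the same scale. The fluoro in place of hydrogen that separates them (a 1.8-fold lower number from compound 1 to compound 3 (0.25 log units; within the scatter)) does not set them apart, so the two stand level. Compound 2 (`Cc1cc2nc(-c3cn(-c4ccccc4)nc3-c3ccccc3)[nH]c2cc1C`) reads much higher at 14500 nM in this assay and is clearly apart from compound 3.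

Compound 4 (`O=C(OCc1ccccc1)c1ccc2[nH]c(-c3cn(-c4ccccc4)nc3-c3ccc(F)cc3)nc2c1`) keeps all of compound 3 but carries benzyloxycarbonyl in place of hydrogen on an aromatic carbon of the fused system (benzyloxycarbonyl in place of hydrogen on an aromatic carbon). Within the data shown here, no measured step tests this group. The fluoro step (a 1.8-fold lower number from compound 1 to compound 3 (0.25 log units; within the scatter)) is small and lies elsewhere in the molecule, so it offers little guidance. Among the measured compounds shown here, the nearest hint is compound 2 at 14500 nM as the only compound substituted on the ring that changes here, and its number is higher than those of compound 1 and compound 3. That is a single comparison with different groups, so only a modest rise is expected, with wide uncertainty. The estimate amounts to a 2.0-fold higher number from compound 3 to compound 4 (0.30 log units; within the scatter) as the expected change. For compound 4 the estimated value is 3000 nM (expected range 700 nM to 14000 nM).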

Compound 4, half-maximal inhibitory concentration: 21500 nM
Beside the measured number, compound 4's estimate is 7.2-fold (0.86 log units) below it; the measured number lies above the stated range.
By their numbers in this assay, from the lowest: compounds 3 and 1 (each within the scatter of the next); then compounds 2 and 4 (each within the scatter of the next).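

In this assay, the aromatic carbon of the six-membered ring in the fused system proves sensitive to this change: benzyloxycarbonyl in place of hydrogen gives a 14-fold higher number from compound 3 to compound 4 (1.15 log units; beyond the scatter), the first single-place step at this ring among the compounds shown. Among these compounds, the earlier fluoro step, a 1.8-fold lower number from compound 1 to compound 3 (0.25 log units; within the scatter), lay elsewhere in the molecule and did not separate its two compounds, so compound 4 is the first case in which one substitution on this scaffold clearly moves the number, and it moves it toward weaker inhibition. Nothing measured here accounts for the rise, and the group enters as a whole, so the ester link and its terminal aromatic ring cannot be told apart as the part that matters.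

The compounds shown leave open whether a carboxylic acid, a methyl ester or a primary amide on the same aromatic carbon would stay near compound 3 at 1510 nM or rise as compound 4 does. They also leave open whether a single fluoro or methoxy group at this carbon would be tolerated, and so whether the loss follows any substituent here or only one as large as benzyloxycarbonyl.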